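The compounds below may be only part of what the source reports. "The series", "measured", "known", "first", "only" and "open" are said of these compounds alone.

Measured compounds:

- Compound 1, `CCCCC#Cc1cc([C@@H]2O[C@H](CO)[C@@H](O)[C@H]2O)n2ncnc(N)c12`, in a functional assay on LN-229 cells (Homo sapiens) for antiproliferative activity, with a stated time of 72 h (on this read-out higher numbers stand for weaker inhibition and lower numbers for stronger inhibition), gives 1000 nM.
- Compound 2, `Nc1ncnn2c([C@@H]3O[C@H](CO)[C@@H](O)[C@H]3O)cc(C#Cc3ccccc3)c12`, in this assay gives 88000 nM.

Of the two numbers, compound 2 has the higher one, and the gap to compound 1 is large: an 88-fold higher number from compound 1 to compound 2 (1.94 log units; beyond the scatter). That single step is the only one available, and it shows that the group on the triple-bonded carbon matters a great deal for this read-out.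

Compound 3, `Nc1ncnn2c([C@@H]3O[C@H](CO)[C@@H](O)[C@H]3O)cc(-c3ccc(Cl)cc3)c12`, has not been measured. Its difference from compound 2 is 4-chlorophenyl in place of 2-phenylethynyl on an aromatic carbon. The triple bond is gone altogether, and a 4-chlorophenyl sits directly on the aromatic carbon. Going by the values given here, no measured step covers such a change; the step from compound 1 to compound 2 only exchanged the group on the triple-bonded carbon. The direction is therefore open, and the estimate for compound 3 must be broad. Compound 3 is expected to give about 20000 nM, plausibly anywhere from 2000 nM to 200000 nM, which would mean a step of a 4.4-fold lower number from compound 2 to compound 3 (0.64 log units; beyond the scatter) and leaves room for either a stronger or a weaker result than compound 2.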

Compound 3, half-maximal inhibitory concentration: 32600 nM
Beside the measured number, compound 3's estimate is 1.6-fold (0.21 log units) below it; the range from low to high includes it.
By their numbers in this assay, from the lowest: compound 1; then compound 3; then compound 2.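

In this assay, the triple bond proves not to be what separates these compounds at this aromatic carbon: putting a 4-chlorophenyl directly on that carbon in place of 2-phenylethynyl gives a 2.7-fold lower number from compound 2 to compound 3 (0.43 log units; beyond the scatter), only a modest shift for so large an exchange. The hex-1-yn-1-yl group of compound 1 still stands well apart, as exchanging it for the same 4-chlorophenyl gives a 33-fold higher number from compound 1 to compound 3 (1.51 log units; beyond the scatter), so among these three compounds, both groups with a six-membered aromatic ring give much weaker inhibition than the open chain, with or without a triple bond. No measurement of any other kind is at hand to explain these steps.

On these data alone, the step to compound 3 removes the triple bond and adds a chlorine at once, so the share of each in the change remains unknown. Also open, as far as these compounds go, is how a longer chain on the triple-bonded carbon, a hexyl chain placed directly on the aromatic carbon, or an amine at this position would compare with the hex-1-yn-1-yl group.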